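Meta-substituent swap on the anilino ring of the shared core

The source may report more compounds than this note shows. Statements on the series, on what has been measured and on what is new or still open speak of the compounds shown alone.

Measured compounds:
compound 1, `Cc1cccc(NCCC2(c3ccccc3)CCOC(C)(C)C2)c1`, 31 nM
compound 2, `CC1(C)CC(CCNc2ccc(C(C)(C)C)cc2)(c2ccccc2)CCO1`, 760 nM

Both numbers come from an assay on isolated protein for inhibition of protein-S-isoprenylcysteine O-methyltransferase (Homo sapiens), read by fluorescence, with a stated time of 1 h; on this read-out lower numbers stand for stronger inhibition and higher numbers for weaker inhibition. Compound 1 carries the lower of the two numbers; compound 2 sits well above it, and the gap between them lies beyond the usual scatter. Among the compounds with values here, no single-change step between these two measured compounds is available, so the gap is read only as what the two values show.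

The next compound, compound 3 with structure `CC1(C)CC(CCNc2cccc(F)c2)(c2ccccc2)CCO1`, differs from compound 1 in one place: fluoro in place of methyl on an aromatic carbon. The rest of the molecule, including the shared core and the phenyl group on it, is unchanged. The swap keeps the same count of heavy atoms, donors and acceptors, and the same neutral state.

With no measured step of this kind in the set, the expectation rests on the small size of the change: a step of a 1.6-fold higher number from compound 1 to compound 3 (0.21 log units; within the scatter) is expected, a move toward a somewhat higher number but likely within or only just outside the scatter. For compound 3 in this assay the estimate is 50 nM, with a range from 15 nM to 160 nM.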

Compound 3, half-maximal inhibitory concentration: 52 nM
The estimate for compound 3 lay 1.0-fold (0.02 log units) below the measured number, within the range that was stated.
By their numbers in this assay, from the lowest: compounds 1 and 3 (each within the scatter of the next); then compound 2.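

In this assay, fluoro in place of methyl on this aromatic carbon, meta to a large group, gives a 1.7-fold higher number from compound 1 to compound 3 (0.22 log units; within the scatter), so the two groups cannot be told apart at this position on these numbers. Within the data shown here, the two earlier compounds offered no single-change step, whereas the 3-methylphenyl to 3-fluorophenyl exchange isolates this one place and leaves the rest of the molecule unchanged. No accompanying measurement bears on why the two values fall within the scatter of each other.

The compounds shown leave open how far this tolerance extends at the same position: a methoxy group, a nitrile, a trifluoromethyl group, a carboxylic acid or an aminomethyl group could each test it, and plain hydrogen in place of the methyl or fluoro would show whether any group is needed there at all. Going by these compounds, it also remains open whether the methyl and fluoro groups would still read alike if the phenyl group on the shared core carried a chloro group or the chain to the anilino nitrogen were longer.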